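Expected Cytotoxicity of Compound 4 from Three Measured Analogues

The source may hold more compounds than are shown below. What is called first, only, known or untested is meant among the compounds shown, and "the series" means these compounds.

Measured compounds:
compound 1, `Cc1nc(C(NC(=O)C(=O)Nc2ccc(Cl)cc2)C2CCNCC2)sc1CCO`: 85400 nM
compound 2, `Cc1ccc(NC(=O)C(=O)NC(c2nc(C)c(CCO)s2)C2CCCCN2)c(F)c1`: > 78800 nM
compound 3, `Cc1ccc(NC(=O)C(=O)NC(c2nc(C)c(CO)s2)C2CCCCN2)c(F)c1`: > 88000 nM

In an ADME assay on TZM-b1 cells (Homo sapiens) for cytotoxicity, read by XTT assay, with a stated time of 3 days (on this read-out higher numbers stand for lower toxicity in this test and lower numbers for higher toxicity in this test), compound 1 gives 85400 nM. For compound 2 the assay reports only a limit, > 78800 nM. For compound 3 the assay likewise reports only a limit, > 88000 nM. The step that the two limits leave unreadable from compound 2 to compound 3 therefore cannot be read, and compound 2 stands only at the limit of > 78800 nM in this assay, at which 1 of the 3 values shown sits, with no measured number of its own.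

Compound 4, `CC(=O)c1ccc(NC(=O)C(=O)NC(c2nc(C)c(CCO)s2)C2CCCCN2)cc1`, differs from compound 2 by 4-acetylphenyl in place of 2-fluoro-4-methylphenyl on an amide-type nitrogen. For the measured compounds named here, no measured step touches this part of the structure: the only step in hand, from compound 2 to compound 3, concerns the saturated chain on the core and is unreadable between its two limits. Nothing in the measured set therefore points to a change beyond the usual scatter, and the three values together sit at or near the limit of the assay.

Compound 4 is accordingly expected to behave like compound 2, with the step that the limit leaves unreadable from compound 2 to compound 4 expected to be small. The estimate for compound 4 is 80000 nM, with a range from 30000 nM to 160000 nM, and a real chance that the assay again reports only a limit.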

Compound 4, half-maximal cytotoxic concentration: > 77300 nM
Compound 4 ended at the assay's limit; the forecaster's own chance of this, stated with the estimate: 60%; the middle value is on the limit's open side.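

Compound 4 gives only a limit in this assay, > 77300 nM. For the compounds shown here, compound 2 also stands only at a limit, so no step from compound 2 to compound 4 can be read. The compounds shown leave open whether 4-acetylphenyl in place of 2-fluoro-4-methylphenyl on an amide-type nitrogen changes the half-maximal cytotoxic concentration at all.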